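A few compounds are considered here, and "the series" means these few. Any claim that something is new, unique, unknown or untested is made for them only; others in the source may bear on it.

Measured compounds:

Compound 1 `Cc1ccc(S(=O)(=O)/C(=C/c2ccc(O)c([N+](=O)[O-])c2)C(=O)c2ccc(Cl)cc2)cc1`: 25000 nM
Compound 2 `Cc1ccc(S(=O)(=O)/C(=C/c2ccc(N(C)C)cc2)C(=O)c2ccc(Cl)cc2)cc1`: its value is a limit of the assay, > 100000 nM
Compound 3 `CN(C)c1ccc(/C=C(/SCc2ccc(F)cc2)C(=O)c2ccc(C(=O)O)cc2)cc1`: 10000 nM

All three were tested in a functional assay on DU-145 cells (Homo sapiens) for inhibition, read by trypan blue exclusion, with a stated time of 96 h; a lower number here means a stronger inhibitor of growth, a higher number a weaker inhibitor of growth. Compound 2 gives only a limit here, (the limit of > 100000 nM in this assay, at which 1 of the 3 values shown sits), so its true number is not known. Compound 1 differs from compound 2 in one place: 4-hydroxy-3-nitrophenyl in place of 4-(dimethylamino)phenyl on a double-bonded chain carbon bound to a double-bonded chain carbon. This change brought an at least 4.0-fold lower number from compound 2 to compound 1 (0.60 log units; beyond the scatter), and since compound 2 sits at a limit, the real step could be larger than that. Compound 3 has the lowest of the two numbers; the difference between its core and that of compound 2 is not broken down here, as they differ in more than one place.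

Compound 4 `O=C(O)c1ccc(C(=O)/C(=C\c2ccc(O)c([N+](=O)[O-])c2)SCc2ccc(F)cc2)cc1` is not yet measured. It relates to compound 3 exactly as compound 1 relates to compound 2: 4-hydroxy-3-nitrophenyl in place of 4-(dimethylamino)phenyl on a double-bonded chain carbon bound to a double-bonded chain carbon. The place is the same, so this is the same change made on a different core. On that basis the expected step in this assay is a 2.5-fold lower number from compound 3 to compound 4 (0.40 log units; beyond the scatter), resting on the step from compound 2 to compound 1, tempered by the fact that one end of that step is only a limit and the core here is different. Compound 4 is therefore expected to give about 4000 nM, most likely between 1500 nM and 10000 nM.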

Compound 4, concentration for 50% growth inhibition: > 100000 nM
Compound 4 was reported as a limit; the forecaster's own chance of this, stated with the estimate: 5%; middle value at least 25-fold (1.39 log units) from the limit.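

In this assay, the change to 4-hydroxy-3-nitrophenyl in place of 4-(dimethylamino)phenyl did not carry from one core to the other, and the two results run in opposite directions: the same change on two cores in this assay, an at least 4.0-fold lower number (0.60 log units; beyond the scatter) from compound 2 to compound 1 and an at least 10-fold higher number (1.00 log units; beyond the scatter) from compound 3 to compound 4, at least 40-fold (1.60 log units) apart, beyond the scatter of two such steps On the core of compound 3, the change brought an at least 10-fold higher number from compound 3 to compound 4 (1.00 log units; beyond the scatter), a clear loss of growth inhibition rather than the gain seen on the other core. Compound 4 gives > 100000 nM, which is a limit of the assay and not a number; the full size of this step is not known, and the earlier step also has one end at a limit, while neither pair shows which difference between the two cores turns the result around.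

The two cores differ in more than one place, and the compounds shown do not separate those places from one another. Going by these compounds, replacing only the carboxylic acid of compound 3 and compound 4 with an amide, while keeping the rest of each molecule unchanged, would be one way to ask whether that part of the core decides the direction of the step, and that question remains open here.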